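Adding a Fluoro Group to Compound 3: An Expectation

A few compounds are considered here, and "the series" means these few. Any claim that something is new, unique, unknown or untested is made for them only; others in the source may bear on it.

compound 1 `COc1cc(OC)c(/C=C/S(=O)(=O)Cc2ccc(OC)c(OC)c2OC)c(OC)c1`: 15000 nM
compound 2 `COc1cc(OC)c(/C=C/S(=O)(=O)Cc2ccc(O)cc2)c(OC)c1`: 20000 nM
compound 3 `COc1ccc(CS(=O)(=O)/C=C/c2ccccc2OC)cc1`: 5000 nM

All three compounds were tested in a functional assay on H157 cells (Homo sapiens) for antiproliferative activity, read by trypan blue exclusion; on this read-out lower numbers stand for stronger inhibition and higher numbers for weaker inhibition. In this assay compound 3 gives 5000 nM, the lowest of the three numbers. In the same assay compound 1 gives 15000 nM and compound 2 gives 20000 nM, and both gaps to compound 3 lie beyond the scatter of repeated measurements. No two of these compounds differ in only one place, so no single-change step can be read from them, and none of them shows what a fluoro group does.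

Compound 4 `COc1ccc(CS(=O)(=O)/C=C/c2ccc(F)cc2OC)cc1` differs from compound 3 in one place: fluoro in place of hydrogen on an aromatic carbon. A change this small, a single fluorine on an aromatic carbon, gives no ground for expecting a large shift in this assay. The step is therefore estimated as a 1.3-fold lower number from compound 3 to compound 4 (0.10 log units; within the scatter), which stays within the scatter. Compound 4 is expected to give about 4000 nM, with a range from 1500 nM to 12000 nM.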

Compound 4, half-maximal inhibitory concentration: 20000 nM
The estimate for compound 4 lay 5.0-fold (0.70 log units) below the measured number, and the stated range ends below it.
By their numbers in this assay, from the lowest: compound 3; then compounds 1, 2 and 4 (each within the scatter of the next).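

In this assay, fluoro in place of hydrogen at this one place on the aromatic ring, para to a large group and meta to a methoxy group, gives a 4.0-fold higher number from compound 3 to compound 4 (0.60 log units; beyond the scatter). This shows that the position is not indifferent to change: even a single added fluorine moves the number beyond the scatter, towards weaker inhibition, and of the two groups compared here, hydrogen gives the stronger inhibition. Nothing at hand explains why the number rises.

From the compounds shown here alone, it remains open whether this rise is particular to fluoro or would also follow from another group at this place, such as a chlorine atom, a methyl group, a hydroxyl group or an amine. Going by these compounds, it also remains open whether fluoro would do the same in the core of compound 1 or the core of compound 2.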